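Ethyl for Chloro on the Amide-Linked Phenyl Ring

This account rests on a few compounds, and the source may have more. Where it says the series, first, only, none or still open, it means among the compounds named here.

Three compounds have been measured in a functional assay on NCI-H1975 cells (Homo sapiens) for inhibition, read by MTT assay, with a stated time of 72 h; a higher number here means a weaker inhibitor, a lower number a stronger inhibitor:
compound 1 `O=C(CSc1nc(Nc2ccccc2)c2ccccc2n1)Nc1ccccc1Br` gives 10300 nM;
compound 2 `O=C(CSc1nc(Nc2ccccc2)c2ccccc2n1)Nc1cccc([N+](=O)[O-])c1` gives 17900 nM;
compound 3 `O=C(CSc1nc(Nc2ccccc2)c2ccccc2n1)Nc1ccc(Cl)cc1` gives 8040 nM.

Compound 3 carries the lowest of the three numbers. The step of a 2.2-fold lower number from compound 2 to compound 3 (0.35 log units; beyond the scatter) is the only one beyond the scatter; the step of a 1.3-fold lower number from compound 1 to compound 3 (0.11 log units; within the scatter) is not, so compound 1 and compound 3 cannot be ranked against each other.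

Compound 4 `CCc1ccc(NC(=O)CSc2nc(Nc3ccccc3)c3ccccc3n2)cc1` differs from compound 3 by ethyl in place of chloro on an aromatic carbon. All three measured steps swap substituents on this same amide-linked phenyl ring, and each stayed small. Going by the values given here, no measured step involves an ethyl group, so the expectation rests on that small spread alone: compound 4 is expected to sit near compound 3, with a step of a 1.0-fold lower number from compound 3 to compound 4 (0.00 log units; within the scatter). The estimate for compound 4 in this assay is 8000 nM, within a range from 3500 nM to 18000 nM.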

Compound 4, half-maximal inhibitory concentration: 9910 nM
For compound 4 the middle estimate is 1.2-fold (0.09 log units) below the measured one, and the stated range covers the measured number.
By their numbers in this assay, from the lowest: compounds 3, 4, 1 and 2 (each within the scatter of the next, the first and the last beyond it).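

In this assay, ethyl in place of chloro gives a 1.2-fold higher number from compound 3 to compound 4 (0.09 log units; within the scatter), so a chlorine on this ring is not required for a number in this range. The other two steps, a 1.0-fold lower number from compound 1 to compound 4 (0.02 log units; within the scatter) and a 1.8-fold lower number from compound 2 to compound 4 (0.26 log units; within the scatter), also lie within the scatter, so the 4-ethylphenyl ring cannot be ranked against either earlier ring. Nothing available here accounts for these numbers. Going by these compounds, whether a longer chain, an amine or a carboxylic acid at this place would move the number beyond the scatter remains open.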